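This account rests on a few compounds, and the source may have more. Where it says the series, first, only, none or still open, it means among the compounds named here.

Measured in a functional assay on CCRF-CEM cells (Homo sapiens) for cytotoxicity, with a stated time of 72 h; on this read-out higher numbers stand for weaker inhibition and lower numbers for stronger inhibition:
Compound 1 `CCOC(=O)/C=C/C=C/C=C/C=C/c1cccn1C`: > 10000 nM, a limit
Compound 2 `CCOC(=O)/C=C/C=C/C=C/C=C/c1nccs1`: > 10000 nM, a limit
Compound 3 `CCOC(=O)/C=C/C=C/C=C/c1[nH]ccc1Cl`: 2420 nM

Compound 2 has no number, only (the limit of > 10000 nM in this assay, at which 2 of the 3 values shown sit). Compound 4 `CCOC(=O)/C=C/C=C/C=C/C=C/c1[nH]ccc1Cl` differs from compound 2 by one change: a group of 6 heavy atoms (4 carbon, 1 nitrogen, 1 chlorine; one five-membered aromatic ring with 1 hetero atom) in place of a group of 5 heavy atoms (3 carbon, 1 nitrogen, 1 sulfur; one five-membered aromatic ring with 2 hetero atoms), on a double-bonded chain carbon bound to a double-bonded chain carbon. For the measured compounds named here, the single measured step, a step that the two limits leave unreadable from compound 1 to compound 2, has no readable size and gives no guide. Going by the values given here, compound 3 carries the entering group on a shorter chain and gives 2420 nM, the only number in this assay. That value points toward stronger inhibition for compound 4, though compound 1 also stands at a limit with the longer chain. The step is expected to be an at least 5.5-fold lower number from compound 2 to compound 4 (0.74 log units; beyond the scatter). For compound 4 the estimated value is 1800 nM, with an expected range of 350 nM to 9000 nM.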

Compound 4, half-maximal inhibitory concentration: 270 nM
Compound 4: middle estimate off by 6.7-fold (0.82 log units), on the high side; the whole stated range lies above it.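

In this assay, placing the chlorine-bearing ring on the longer chain in place of 1,3-thiazol-2-yl gives an at least 37-fold lower number from compound 2 to compound 4 (1.56 log units; beyond the scatter). Placing the same ring there in place of 1-methyl-1H-pyrrol-2-yl gives an at least 37-fold lower number from compound 1 to compound 4 (1.56 log units; beyond the scatter), so the longer chain does not by itself hold the read-out at the limit. Compound 1 and compound 2 each stand at a limit, not a number: the limit of > 10000 nM in this assay, at which 2 of the 4 values shown sit.

Whether the chlorine or the hydrogen-bond donor of the ring accounts for this change stays open. Also open, from the compounds shown here alone, is what a bromine or a methyl in place of that chlorine would give.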